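The compounds below may be only part of what the source reports. "The series", "measured", "known", "first", "only" and "open" are said of these compounds alone.

Measured compounds: compound 1 `O=C1O/C(=C\Cn2cc(-c3cc(F)cc(F)c3)nn2)C(OCc2ccccc2)=C1OCc1ccccc1`; compound 2 `CCCCc1cn(C[C@H](O)[C@H]2OC(=O)C(OCc3ccccc3)=C2OCc2ccccc2)nn1`; compound 3 `Cc1ccc(S(=O)(=O)NCc2cn(C[C@H](O)[C@H]3OC(=O)C(OCc4ccccc4)=C3OCc3ccccc3)nn2)cc1`.

In a functional assay on HCT-116 cells (Homo sapiens) for antiproliferative activity, read by MTT assay, with a stated time of 72 h (a lower number here means a stronger inhibitor, a higher number a weaker inhibitor), compound 2 gives 10400 nM. Compound 3 gives 13100 nM. For compound 1 the assay reports only a limit, > 100000 nM; this is the limit of > 100000 nM in this assay, at which 1 of the 3 values shown sits. Compound 2 holds the lowest of the two numbers shown, and its step to compound 3, a 1.3-fold higher number from compound 2 to compound 3 (0.10 log units; within the scatter), stays within the scatter. Compound 4 `O=C1O[C@H]([C@@H](O)Cn2cc(CCO)nn2)C(OCc2ccccc2)=C1OCc1ccccc1` differs from compound 2 as follows: hydroxy in place of ethyl on a saturated chain carbon, two bonds along the chain from an aromatic carbon. For the measured compounds named here, the only measured step at a comparable place, a 1.3-fold higher number from compound 2 to compound 3 (0.10 log units; within the scatter), stayed within the scatter while swapping a far larger group than the one here. The resulting step is therefore expected to be small: a 1.4-fold higher number from compound 2 to compound 4 (0.16 log units; within the scatter). The estimate for compound 4 is 15000 nM, with a range from 5000 nM to 50000 nM.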

Compound 4, half-maximal inhibitory concentration: 72700 nM
Estimate against measurement, compound 4: 4.8-fold (0.69 log units) below, and the stated range ends below it.
By their numbers in this assay, from the lowest: compounds 2 and 3 (each within the scatter of the next); then compound 4. At a limit, above all of these: compound 1.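

This position is less forgiving than the earlier pair suggested: in this assay, changing butyl to 2-hydroxyethyl gives a 7.0-fold higher number from compound 2 to compound 4 (0.84 log units; beyond the scatter), beyond the scatter although only a small group changes. The much larger ((4-methylphenyl)sulfonyl)amino group offers no such contrast with hydroxymethyl, which gives a 5.5-fold higher number from compound 3 to compound 4 (0.74 log units; beyond the scatter), so group size alone does not track the numbers across these compounds. Nothing shown here gives a cause for this loss. Still open, as far as these compounds go, is whether the hydroxy group or the shorter chain matters more. A propyl chain, or an amine or methoxy group at the chain end, would help separate the two.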